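Moving a methyl group on compound 1

The source may report more compounds than this note shows. Statements on the series, on what has been measured and on what is new or still open speak of the compounds shown alone.

- compound 1 `COc1cc(C(=O)c2cn(-c3cccc(C)c3)cc2-c2ccsc2)cc(OC)c1OC`: 65 nM
- compound 2 `COc1cc(C(=O)c2cn(-c3cccc(C)c3)cc2-c2ccoc2)cc(OC)c1OC`: 21 nM

Going by the values given here, in a functional assay on MCF7 cells (Homo sapiens) for inhibition, with a stated time of 96 h (a lower number here means a stronger inhibitor, a higher number a weaker inhibitor), compound 1 gives 65 nM, the higher of the two numbers known so far, which makes it the weaker inhibitor of the pair. Compound 3 `COc1cc(C(=O)c2cn(-c3ccc(C)cc3)cc2-c2ccsc2)cc(OC)c1OC` has not been measured yet. It differs from compound 1 by one change: 4-methylphenyl in place of 3-methylphenyl on an aromatic nitrogen. In words, 4-methylphenyl stands in place of 3-methylphenyl on an aromatic nitrogen. Among the compounds with values here, the one measured step, a 3.1-fold lower number from compound 1 to compound 2 (0.49 log units; beyond the scatter), came with furan-3-yl in place of thiophen-3-yl on an aromatic carbon. That is a different place from this change, so it gives no direction and serves only as a rough guide to size. A shift within the scatter is therefore expected, with no direction favoured. The expected step is a 1.1-fold higher number from compound 1 to compound 3 (0.03 log units; within the scatter). For compound 3, the estimated value is 70 nM, with an expected range from 25 nM to 200 nM.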

Compound 3, half-maximal inhibitory concentration: 4 nM
Compound 3: middle estimate off by 18-fold (1.24 log units), on the high side, and the stated range ends above it.
By their numbers in this assay, from the lowest: compound 3; then compound 2; then compound 1.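

Within this assay, the position of the methyl group on the phenyl ring attached to the aromatic nitrogen turns out to matter greatly: 4-methylphenyl in place of 3-methylphenyl gives a 16-fold lower number from compound 1 to compound 3 (1.21 log units; beyond the scatter). The two groups have the same atoms and the same counts, so this large step comes from moving the methyl group alone, and it exceeds the earlier step on the aromatic carbon, a 3.1-fold lower number from compound 1 to compound 2 (0.49 log units; beyond the scatter). Nothing available here explains why moving the methyl group has this effect.

From the compounds shown here alone, it remains open whether the same change would have a similar effect on compound 2, which carries furan-3-yl. Also open, going by these compounds, is how a longer chain such as ethyl, an amine or a carboxylic acid would behave in place of the methyl group of compound 3.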